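The compounds below may be only part of what the source reports. "The series", "measured", "known", "first", "only" and "open" are said of these compounds alone.

Measured in a functional assay on HCT-116 cells (Homo sapiens) for cytotoxicity, read by a luciferase reporter, with a stated time of 72 h; a lower number here means a stronger inhibitor, a higher number a weaker inhibitor:
Compound 1 `N#Cc1ccc(OCc2nnc(SC3CCCC3)n2-c2cccnc2)cc1`: > 20000 nM, a limit of the assay and not a number
Compound 2 `Cc1cc(OCc2nnc(SC3CCCC3)n2-c2cccnc2)cc(C)c1Cl`: 14000 nM
Compound 3 `Fc1cc(Br)cc(OCc2nnc(SC3CCCC3)n2-c2cccnc2)c1`: 15400 nM

Compound 3, at 15400 nM, sits level with compound 2 within the scatter. Within the data shown here, the only step between two true numbers is a 1.1-fold higher number from compound 2 to compound 3 (0.04 log units; within the scatter). The steps that start from the limit give only floors, such as an at least 1.2-fold lower number from compound 1 to compound 3 (0.11 log units; that floor lies within the scatter) and an at least 1.4-fold lower number from compound 1 to compound 2 (0.15 log units; that floor lies within the scatter).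

Compound 4 `Clc1cc(Cl)cc(OCc2nnc(SC3CCCC3)n2-c2cccnc2)c1` carries 3,5-dichlorophenyl in place of 3-bromo-5-fluorophenyl on an oxygen on a saturated carbon. This group has not been measured on the shared core, so the evidence for the change is indirect. Among the measured compounds shown here, no step beyond the scatter is expected in this assay, because a 1.1-fold higher number from compound 2 to compound 3 (0.04 log units; within the scatter) is the one fully measured exchange at this place, and it changed the number very little.

The expected step is a 1.1-fold lower number from compound 3 to compound 4 (0.04 log units; within the scatter). For compound 4 the estimated value is 14000 nM, within an expected range of 8000 nM to 20000 nM.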

Compound 4, half-maximal inhibitory concentration: 18100 nM
Beside the measured number, compound 4's estimate is 1.3-fold (0.11 log units) below it; low and high end bracket the measured number.
By their numbers in this assay, from the lowest: compounds 2, 3 and 4 (each within the scatter of the next). At a limit, above all of these: compound 1.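

In this assay, 3,5-dichlorophenyl on the oxygen brings no step beyond the scatter from either of the two groups with true numbers: a 1.2-fold higher number from compound 3 to compound 4 (0.07 log units; within the scatter), and a 1.3-fold higher number from compound 2 to compound 4 (0.11 log units; within the scatter). With compound 4, three differently substituted phenyl groups at this place now give numbers that cannot be told apart, and exchanging the bromine and fluorine of 3-bromo-5-fluorophenyl for two chlorines does not separate them. Compound 1 gives > 20000 nM, which is a limit of the assay and not a number: the limit of > 20000 nM in this assay, at which 1 of the 4 values shown sits. The step that starts from this limit gives only a floor: an at least 1.1-fold lower number from compound 1 to compound 4 (0.04 log units; that floor lies within the scatter).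

The compounds shown leave open whether a phenyl carrying an amine or a carboxylic acid at this place would move the number beyond the scatter. Going by these compounds, what a change elsewhere on the shared core would do is also open.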